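The source may report more compounds than this note shows. Statements on the series, on what has been measured and on what is new or still open speak of the compounds shown alone.

Of the compounds shown here, three built on one shared core have been tested in a functional assay on MGC-803 cells (Homo sapiens) for inhibition, read by MTT assay, with a stated time of 72 h; a lower number here means a stronger inhibitor, a higher number a weaker inhibitor. Compound 1 `Cc1cc(Nc2cc(-c3ccccc3)[nH]n2)n2nc(SCCCc3ccccc3)nc2n1` gives 6510 nM. Compound 2 `Cc1cc(Nc2cc(-c3ccccc3)[nH]n2)n2nc(SCc3ccc([N+](=O)[O-])cc3)nc2n1` gives 4250 nM, and compound 3 `Cc1cc(Nc2cc(-c3ccccc3)[nH]n2)n2nc(SCc3ccc(Cl)cc3)nc2n1` gives 3950 nM. Compound 2 holds the second highest of these three numbers, yet every gap is small: a 1.5-fold lower number from compound 1 to compound 2 (0.19 log units; within the scatter), a 1.6-fold lower number from compound 1 to compound 3 (0.22 log units; within the scatter) and a 1.1-fold lower number from compound 2 to compound 3 (0.03 log units; within the scatter). The unmeasured compound 4 `Cc1cc(Nc2cc(-c3ccccc3)[nH]n2)n2nc(SCc3nc4ccccc4[nH]3)nc2n1` differs from compound 2 in one place: 1H-benzimidazol-2-yl in place of 4-nitrophenyl on a saturated chain carbon bound to a sulfur. Among the measured compounds shown here, all the measured steps also swap the group on the saturated chain carbon bound to a sulfur, and none moved the number beyond the scatter, so no step beyond the scatter is expected here either, even though the 1H-benzimidazol-2-yl group brings one hydrogen-bond donor. Compound 4 is therefore estimated at 4000 nM, with a range of 1500 nM to 10000 nM, which is expected to mean a 1.1-fold lower number from compound 2 to compound 4 (0.03 log units; within the scatter).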

Compound 4, half-maximal inhibitory concentration: 1790 nM
The estimate for compound 4 lay 2.2-fold (0.35 log units) above the measured number; measured number inside the range.
By their numbers in this assay, from the lowest: compound 4; then compounds 3, 2 and 1 (each within the scatter of the next).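

In this assay, among the compounds shown here, the 1H-benzimidazol-2-yl group on a saturated chain carbon bound to a sulfur brings a 2.4-fold lower number from compound 2 to compound 4 (0.38 log units; beyond the scatter) and a 2.2-fold lower number from compound 3 to compound 4 (0.34 log units; beyond the scatter) and a 3.6-fold lower number from compound 1 to compound 4 (0.56 log units; beyond the scatter) and is the first change at this place to pass the scatter, though each step is modest. Unlike 4-nitrophenyl, it carries a hydrogen-bond donor and a five-membered aromatic ring, and these compounds cannot show which feature, if either, matters. Nothing measured here accounts for the lower number. On these data alone, what a 1-methyl-1H-benzimidazol-2-yl or an imidazol-2-yl group would do at this place stays open.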